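This account rests on a few compounds, and the source may have more. Where it says the series, first, only, none or still open, it means among the compounds named here.

In a functional assay on MCF7 cells (Homo sapiens) for antiproliferative activity, read by MTT assay, with a stated time of 48 h (on this read-out lower numbers stand for stronger inhibition and higher numbers for weaker inhibition), the measured compounds give the following:

- Compound 1 `COc1ccc(-c2nc3cccc(-c4cc(OC)c(OC)c(OC)c4)c3o2)cc1` gives > 25000 nM (a limit)
- Compound 2 `COc1cc(-c2cccc3nc(-c4ccc(F)cc4)oc23)cc(OC)c1OC` gives > 25000 nM (a limit)
- Compound 3 `COc1cc(-c2cccc3nc(-c4ccc(Br)cc4)oc23)cc(OC)c1OC` gives > 25000 nM (a limit)

Compound 3 stands at > 25000 nM as a limit and not as a number. With the limit of > 25000 nM in this assay, at which 3 of the 3 values shown sit, as the only reference point, the measured set offers no ranking.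

The change to compound 4 `COc1cc(-c2cccc3nc(-c4cccc(O)c4)oc23)cc(OC)c1OC` is 3-hydroxyphenyl in place of 4-bromophenyl on an aromatic carbon of the five-membered aromatic ring, counted as 3-hydroxyphenyl in place of 4-bromophenyl on an aromatic carbon and leaving the rest of the structure untouched.

The steps a step that the two limits leave unreadable from compound 1 to compound 2 and a step that the two limits leave unreadable from compound 1 to compound 3 and a step that the two limits leave unreadable from compound 2 to compound 3 bear on it: each alters that same group, yet none has a readable size. Among the compounds with values here, no measured compound carries the 3-hydroxyphenyl group.

With compound 3 at > 25000 nM as a limit, compound 4 is expected to stay close to that limit, with no clear move in either direction. In this assay the estimated change is a number no higher from compound 3 to compound 4 (the limit leaves the size open) and these data support no more. The estimated value for compound 4 is 25000 nM within an expected range of 9000 nM to 60000 nM.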

Compound 4, half-maximal inhibitory concentration: > 25000 nM
Compound 4 gave a limit, no number; the forecaster's own chance of this, stated with the estimate: 70%; the middle value lies on the limit itself.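

In this assay compound 4 gives > 25000 nM as a limit and not a number. Within the data shown here, no step from compound 1, compound 2 or compound 3 to compound 4 can be read, since all rest on one limit: the limit of > 25000 nM in this assay, at which 4 of the 4 values shown sit. The compounds shown leave open whether changing this group on the shared core alters activity at all.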